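Removing a Methyl Group from a Weakly Inhibiting Series

The compounds below may be only part of what the source reports. "The series", "measured", "known", "first", "only" and "open" are said of these compounds alone.

Three related compounds have been tested in a functional assay, read by spectrophotometry, with a stated time of 5 min; on this read-out higher numbers stand for weaker inhibition and lower numbers for stronger inhibition. Compound 1, `Cc1ccc2[nH]c(=O)c(/C=N/c3ccc(O)cc3)cc2c1`, gives 235000 nM in this assay. Compound 2, `O=c1[nH]c2ccccc2cc1/C=N/c1ccc(O)cc1`, gives 306000 nM in this assay. Compound 3, `Cc1ccc2[nH]c(=O)c(/C=N/Cc3ccccc3)cc2c1`, gives 310000 nM in this assay. All three numbers lie close together, and none of the differences among them reaches beyond the usual scatter of repeated measurements.

Compound 2 differs from compound 1 by a single change, (hydrogen in place of methyl on an aromatic carbon), and that change produced a 1.3-fold higher number from compound 1 to compound 2 (0.11 log units; within the scatter). Compound 3 differs from compound 1 in its core, and the difference between the two cores is benzyl in place of 4-hydroxyphenyl on a double-bonded nitrogen, which gave a 1.3-fold higher number from compound 1 to compound 3 (0.12 log units; within the scatter).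

Compound 4, `O=c1[nH]c2ccccc2cc1/C=N/Cc1ccccc1`, has not yet been measured in this assay. It differs from compound 3 by hydrogen in place of methyl on an aromatic carbon. This is the same change that turns compound 1 into compound 2; the place of the change is described in the same words in both cases, so it counts as the same change made on the other core.

Because the earlier instance of this change gave only a 1.3-fold higher number from compound 1 to compound 2 (0.11 log units; within the scatter), a step of similar size is expected here, namely a 1.2-fold higher number from compound 3 to compound 4 (0.09 log units; within the scatter). On that basis compound 4 is estimated to give about 380000 nM in this assay. The expected range for compound 4 runs from 200000 nM to 750000 nM, since one small step cannot fix the direction firmly.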

Compound 4, half-maximal inhibitory concentration: 329000 nM
Estimate against measurement, compound 4: 1.2-fold (0.06 log units) above; measured number inside the range.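

In this assay, putting hydrogen in place of methyl on the core of compound 3 gave a 1.1-fold higher number from compound 3 to compound 4 (0.03 log units; within the scatter), and this step agrees with the earlier instance of the same change on the other core: the same change on two cores in this assay, a 1.3-fold higher number (0.11 log units; within the scatter) from compound 1 to compound 2 and a 1.1-fold higher number (0.03 log units; within the scatter) from compound 3 to compound 4, 1.2-fold (0.09 log units) apart, within the scatter of two such steps. So far the change carries across both cores in the same modest way: in neither pair can the two numbers be told apart from the ordinary spread of repeated measurements. This does not show that the methyl group has a real effect of a set size that transfers from core to core, since two steps this small could agree simply by lying within the scatter, and two pairs cannot establish a rule for the series.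

Going by these compounds, it remains open whether a different group on that aromatic carbon, such as a chlorine atom, a methoxy group or a longer chain, would give a step beyond the scatter. On these data alone, it is equally open whether a group other than 4-hydroxyphenyl or benzyl on the double-bonded nitrogen, such as one carrying an amine or a carboxylic acid, would change how the methyl-to-hydrogen swap behaves.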